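The source may hold more compounds than are shown below. What is called first, only, known or untested is meant among the compounds shown, and "the series" means these compounds.

Measured so far in a functional assay on A549 cells (Homo sapiens) for inhibition, read by CCK-8 assay, with a stated time of 72 h, tested at 10 uM; on this read-out lower numbers stand for a weaker effect and higher numbers for a stronger effect at the one concentration tested:
- compound 1 `CN(C)C(=O)c1cc2cnc(Nc3ccc(C(=O)NCCCN=C=S)cc3)nc2n1C1CCCC1`: 103%
- compound 2 `CN(C)C(=O)c1cc2cnc(Nc3ccc(C(=O)NCCCCCCCN=C=S)cc3)nc2n1C1CCCC1`: 101%
- compound 3 `CN(C)C(=O)c1cc2cnc(Nc3ccc(C(=O)NCCCN=C=S)cc3F)nc2n1C1CCCC1`: 60.2%

Compound 1 gives the highest of the three numbers in this assay. Compound 2 sits within the scatter of it, a number 2 percentage points lower from compound 1 to compound 2 (within the scatter). Compound 3 lies well apart, a number 42.8 percentage points lower from compound 1 to compound 3 (beyond the scatter), a large step.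

Compound 4 `CN(C)C(=O)c1cc2cnc(Nc3ccc(NC(=O)CCCCN=C=S)cc3)nc2n1C1CCCC1` differs from compound 1 in the following way: a group of 10 heavy atoms (6 carbon, 2 nitrogen, 1 oxygen, 1 sulfur; no ring) in place of a group of 9 heavy atoms (5 carbon, 2 nitrogen, 1 oxygen, 1 sulfur; no ring), on an aromatic carbon The new group sits on an aromatic carbon of a six-membered aromatic ring of carbon only, para to a large group.

Neither measured step covers this change directly. The step from compound 1 to compound 2 shows that a change in chain length along this group stays within the scatter, while the step from compound 1 to compound 3 concerns a fluoro on the ring and not this group. The present change rearranges the group itself, which no pair tests, so some loss beyond the scatter is possible but not shown.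

Compound 4 is therefore expected at 85%, in the range 50% to 105%, an expected step of a number 18 percentage points lower from compound 1 to compound 4 (beyond the scatter).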

Compound 4, a percentage reported as inhibition, at one concentration (the size of the read-out at that concentration, not a potency): 102%
Beside the measured number, compound 4's estimate is 17 percentage points below it; low and high end bracket the measured number.
By their numbers in this assay, from the lowest: compound 3; then compounds 2, 4 and 1 (each within the scatter of the next).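

The result in this assay reads a number 1 percentage points lower from compound 1 to compound 4 (within the scatter) and so shows that, on this aromatic carbon para to a large group, the group of 10 heavy atoms is tolerated as well as the group of 9 heavy atoms it replaces. The earlier compounds shown here kept the amide in one orientation, whereas here it is turned round, with the nitrogen rather than the carbonyl on the ring, and the step stays within the scatter. Nothing available explains this tolerance.

From the compounds shown here alone, whether the turned amide also tolerates a ring fluoro stays open, as does whether an amine or a carboxylic acid could replace the isothiocyanate at the chain end. With a single tested concentration, any difference in the size of the effect among compound 1, compound 2 and compound 4 at other concentrations remains unresolved.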